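A few compounds are considered here, and "the series" means these few. Any claim that something is new, unique, unknown or untested is made for them only; others in the source may bear on it.

Working notes on the series. Among the compounds with values here, in a functional assay on MCF7 cells (Homo sapiens) for antiproliferative activity (a higher number here means a weaker inhibitor, a lower number a stronger inhibitor), compound 3 `CC(C)=CCc1cc(C(=O)Nc2cc3ccc(OCCCN(C)C(C)C)c(C)c3oc2=O)ccc1O` gives 1050 nM, which stands second highest of the three numbers so far; compound 2 `CC(=O)Oc1ccc(C(=O)Nc2cc3ccc(OCC4CCCNC4)c(C)c3oc2=O)cc1CC=C(C)C` gives 820 nM and compound 1 `CC(=O)Oc1ccc(C(=O)Nc2cc3ccc(OCC4CCCN(C)C4)c(C)c3oc2=O)cc1CC=C(C)C` gives 1650 nM, and both lie within the scatter of compound 3. Compound 4 `CC(C)=CCc1cc(C(=O)Nc2cc3ccc(OCCCN(C)Cc4ccccc4)c(C)c3oc2=O)ccc1O` differs from compound 3 by benzyl in place of isopropyl on an amine nitrogen. Within the data shown here, the only measured step, a 2.0-fold lower number from compound 1 to compound 2 (0.30 log units; within the scatter), concerns hydrogen in place of methyl on an amine nitrogen in a ring and stays within the scatter; it does not touch the exchange of isopropyl for benzyl, so no step beyond the scatter is expected in this assay. Staying close to compound 3, compound 4 is expected at 1050 nM, with a range from 400 nM to 2800 nM, meaning an expected step of no change at the digits printed from compound 3 to compound 4 (within the scatter).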

Compound 4, half-maximal inhibitory concentration: 11500 nM
Compound 4: middle estimate off by 11-fold (1.04 log units), on the low side; the measured number lies above the stated range.
By their numbers in this assay, from the lowest: compounds 2, 3 and 1 (each within the scatter of the next); then compound 4.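

In this assay, the group on this amine nitrogen matters: benzyl in place of isopropyl gives an 11-fold higher number from compound 3 to compound 4 (1.04 log units; beyond the scatter), so this position does not tolerate every exchange. With a single pair, the effect of the six-membered aromatic ring cannot be separated from that of the added carbons. Nothing at hand accounts for the step. Open, on these data alone, is whether a saturated cyclohexylmethyl group on the same nitrogen would follow benzyl or stay with isopropyl. Also open, as far as these compounds go, is how an ethyl group or a hydrogen there would read.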